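From Hydroxyamino to Benzylsulfanyl on the Fused Core

The compounds below may be only part of what the source reports. "The series", "measured", "known", "first", "only" and "open" are said of these compounds alone.

Compound 1 `Cc1ccc(-c2nc(NO)c3cc(Cl)ccc3n2)cc1` was examined in a functional assay on HepG2 cells (Homo sapiens) for antiproliferative activity, read by MTT assay, with a stated time of 48 h (a lower number here means a stronger inhibitor, a higher number a weaker inhibitor), where compound 1 gives 23.1 ug/mL. Among the three measured compounds this is the highest number. Compound 2 `Cc1ccc(-c2nc3ccc(Cl)cc3c(=O)n2N)cc1` comes nearest: in this assay compound 2 gives 18.4 ug/mL, and the two values lie within the usual scatter of each other. Compound 3 `Cc1ccc(C(=O)Nc2ccc(Cl)cc2C(=S)NN)cc1` gives 5.59 ug/mL in this assay, a lower number that lies beyond the scatter from compound 1.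

Compound 4 `Cc1ccc(-c2nc(SCc3ccccc3)c3cc(Cl)ccc3n2)cc1` has not yet been measured. It differs from compound 1 in one place: benzylsulfanyl in place of hydroxyamino on an aromatic carbon. Among the compounds with values here, no step between two measured compounds covers this change. The expectation rests on the value of compound 1, 23.1 ug/mL, and on the spread of the three numbers. The expected step, a 1.4-fold lower number from compound 1 to compound 4 (0.16 log units; within the scatter), is modest, most likely toward a lower number, though it may not reach beyond the scatter. On that basis compound 4 is estimated at 16 ug/mL in this assay, with a range from 6 ug/mL to 45 ug/mL.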

Compound 4, half-maximal inhibitory concentration: 18.4 ug/mL
Beside the measured number, compound 4's estimate is 1.2-fold (0.06 log units) below it, and the stated range covers the measured number.
By their numbers in this assay, from the lowest: compound 3; then compounds 2, 4 and 1 (each within the scatter of the next).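

In this assay, placing benzylsulfanyl instead of hydroxyamino on the aromatic carbon next to the ring nitrogen gives a 1.3-fold lower number from compound 1 to compound 4 (0.10 log units; within the scatter). Within the data shown here, this is the first step here between two compounds that differ in one place, and it shows that at this position a group of 8 heavy atoms with a six-membered aromatic ring and 0 hydrogen-bond donors leaves the number within the scatter of that found with a group of 2 heavy atoms and 2 hydrogen-bond donors. No measurement at hand explains why the two numbers lie so close.

On these data alone, how a plain amine or a methylsulfanyl group would read at this position remains open, as does the effect of a chlorine on the benzyl ring. Compound 3 differs from compound 1 and compound 4 in more than one place, so its number cannot be tied to any single change.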